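Swapping methoxy for fluoro on compound 2

A few compounds are considered here, and "the series" means these few. Any claim that something is new, unique, unknown or untested is made for them only; others in the source may bear on it.

Compound 1 `Cc1cc(Br)ccc1C(=O)Nc1ccccn1` gives > 100 ug/mL as a limit of the assay, not a number
Compound 2 `COc1ccc(NC(=O)c2ccccc2C)nc1` gives 12.5 ug/mL as its measured number
Compound 3 `Cc1c(F)cccc1C(=O)Nc1ccccn1` gives 25 ug/mL as its measured number

Compound 2 gives 12.5 ug/mL and compound 3 gives 25 ug/mL in a physicochemical assay for solubility, read by nephelometry, measured as kinetic solubility, at pH 6.5, tested at 10 mg/mL (on this read-out lower numbers stand for lower solubility and higher numbers for higher solubility), and these two numbers lie within the usual scatter of each other. Compound 1 offers no number for comparison, only a limit.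

Compound 4 `Cc1ccccc1C(=O)Nc1ccc(F)cn1` has not yet been measured. It differs from compound 2 at one place fluoro in place of methoxy on an aromatic carbon on the shared core: fluoro in place of methoxy on an aromatic carbon, two atoms from the ring nitrogen and para to a large group. Among the compounds with values here, no measured pair shows this change alone, so the guidance is thin. Compound 3 also carries a fluoro, though at another place, and gives 25 ug/mL in this assay so a small rise close to the scatter is expected. The estimated change a 2.0-fold higher number from compound 2 to compound 4 (0.30 log units; within the scatter) is therefore modest. Compound 4 is estimated at 25 ug/mL with an expected range from 8 ug/mL to 90 ug/mL as its likely span.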

Compound 4, solubility: 25 ug/mL
For compound 4 middle estimate and measured number coincide at the digits printed; measured number inside the range.
By their numbers in this assay, from the lowest: compounds 2, 3 and 4 (each within the scatter of the next). At a limit, above all of these: compound 1.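

In this assay, within the data shown here, the new pair gives the first step in which only one place on the shared core changes: a 2.0-fold higher number from compound 2 to compound 4 (0.30 log units; within the scatter). At this position, two atoms from the ring nitrogen and para to a large group, fluoro can stand in place of methoxy with no difference beyond the scatter, even though the hydrogen-bond acceptor of the methoxy and one of its heavy atoms are gone. This is a single pair, so it describes this change at this position and no general rule.

On these data alone, whether an amine, a carboxylic acid or a longer chain at this position would move the number beyond the scatter stays open, as does the effect of the same change elsewhere on the shared core. Compound 1 cannot settle either question, since its value is a limit and not a number: the limit of > 100 ug/mL in this assay, at which 1 of the 4 values shown sits.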